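Isopropyl to propyl on the nitrogen of compound 2

The source may report more compounds than this note shows. Statements on the series, on what has been measured and on what is new or still open speak of the compounds shown alone.

In a functional assay on MOLT-4 cells (Homo sapiens) (a lower number here means a stronger inhibitor, a higher number a weaker inhibitor), compound 1 (`COc1ncnc2c1ncn2C[C@@H]1C[C@H](CO)c2ccccc21`) gives 24 ug/mL. Compound 2 (`CC(C)Nc1ncnc2c1ncn2C[C@@H]1C[C@H](CO)c2ccccc21`) gives 24 ug/mL, level with compound 1 at the digits available. Compound 3 (`CCCNc1ncnc2c1ncn2C[C@@H]1C[C@H](CO)c2ccccc21`) has not yet been measured. Its difference from compound 2 is propyl in place of isopropyl on a nitrogen on an aromatic ring, with the same atoms joined differently.

Among the compounds with values here, only one measured step bears on this change, and only indirectly. In that step, no change at the digits printed from compound 1 to compound 2 (within the scatter), isopropylamino takes the place of methoxy on an aromatic carbon, and the result lies within the scatter. Within the data shown here, no measured pair varies the chain on the nitrogen itself, so the series offers no direct precedent. Among the measured compounds shown here, with the step of no change at the digits printed from compound 1 to compound 2 (within the scatter) as the only guide, no shift beyond the scatter is expected in this assay, and neither direction is favoured. The expected step is no change at the digits printed from compound 2 to compound 3 (within the scatter). For compound 3 the estimated value is 24 ug/mL, with an expected range from 12 ug/mL to 50 ug/mL.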

Compound 3, half-maximal inhibitory concentration: 24 ug/mL
Beside the measured number, compound 3's estimate shows no gap at the digits printed; the range from low to high includes it.
By their numbers in this assay, from the lowest: compounds 1, 2 and 3 (each within the scatter of the next).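

Isopropyl to propyl on the nitrogen is the first direct test of the chain at this position: in this assay the change gives no change at the digits printed from compound 2 to compound 3 (within the scatter) and so, for this pair, the way the same atoms are joined does not show in the read-out. The second amine in the set gives the same picture against the methoxy compound, showing no change at the digits printed from compound 1 to compound 3 (within the scatter) and thus adding a second comparison with no shift beyond the scatter to the one already available for isopropylamino. No supporting measurement is available to explain this flat result.

These compounds do not establish whether any group at this position can move the value in this assay beyond the scatter, since only methoxy, isopropylamino and propylamino have been compared here. A longer chain such as octyl on the nitrogen, a cyclohexyl group in place of propyl, or an unsubstituted amine on the same aromatic carbon would test how far this flat response extends.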